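The source may report more compounds than this note shows. Statements on the series, on what has been measured and on what is new or still open speak of the compounds shown alone.

The measured compounds and their values in a functional assay on cells (T-cell, Mus musculus, strain BALB/c) for inhibition, read by MTT assay, with stated times of 24 h and 72 h; a lower number here means a stronger inhibitor, a higher number a weaker inhibitor:

Compound 1 `COc1cc(-c2nnc(SCc3cccc(Cl)c3)o2)ccc1O` gives 8290 nM.
Compound 2 `COc1cc(-c2nnc(SCc3ccccc3Br)o2)ccc1O` gives 17800 nM.
Compound 3 `COc1cc(-c2nnc(SCc3ccc(F)cc3)o2)ccc1O` gives 8190 nM.

Compound 3 has the lowest of the three numbers, but its standing is only partly distinct: the step of a 1.0-fold lower number from compound 1 to compound 3 (0.01 log units; within the scatter) is within the scatter, so compound 1 and compound 3 cannot be separated, while the step of a 2.2-fold lower number from compound 2 to compound 3 (0.34 log units; beyond the scatter) is beyond the scatter and sets compound 2 apart as the weaker inhibitor of the set.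

Compound 4 `COc1cc(-c2nnc(SCc3ccccc3Cl)o2)ccc1O` has not been measured. It differs from compound 3 in one place: 2-chlorophenyl in place of 4-fluorophenyl on a saturated chain carbon bound to a sulfur

Among the compounds with values here, two measured steps bear on this change. The step of a 2.1-fold higher number from compound 1 to compound 2 (0.33 log units; beyond the scatter) shows a modest rise in the number when a halogen sits on the 2-bromophenyl rather than the 3-chlorophenyl, and the step of a 2.2-fold lower number from compound 2 to compound 3 (0.34 log units; beyond the scatter) shows the same size of difference in the opposite direction between 2-bromophenyl and 4-fluorophenyl. Compound 4 carries 2-chlorophenyl, the pattern closest to that of compound 2, so a modest upward step in this assay is expected, of roughly the size seen for compound 2. The estimate for compound 4 is therefore 14000 nM, with a range from 7000 nM to 28000 nM, which corresponds to an expected step of a 1.7-fold higher number from compound 3 to compound 4 (0.23 log units; within the scatter).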

Compound 4, half-maximal inhibitory concentration: 8430 nM
Estimate against measurement, compound 4: 1.7-fold (0.22 log units) above, and the stated range covers the measured number.
By their numbers in this assay, from the lowest: compounds 3, 1 and 4 (each within the scatter of the next); then compound 2.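

In this assay the step of a 1.0-fold higher number from compound 3 to compound 4 (0.01 log units; within the scatter) and the step of a 1.0-fold higher number from compound 1 to compound 4 (0.01 log units; within the scatter) both lie within the scatter, so on a saturated chain carbon bound to a sulfur, 2-chlorophenyl cannot be told apart from either 4-fluorophenyl or 3-chlorophenyl. The earlier compounds left open whether the higher number of compound 2 belonged to the place of the halogen on the ring or to the halogen itself, and the step of a 2.1-fold lower number from compound 2 to compound 4 (0.32 log units; beyond the scatter) for chloro in place of bromo on an aromatic carbon shows that, among these four compounds, only 2-bromophenyl stands apart. No measured evidence is at hand to explain this difference between chloro and bromo.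

As far as these compounds go, all four compounds carry a single halogen on the phenyl ring, so it remains open whether a methoxy group, an amine or a carboxylic acid there would stay level with compound 3 or shift the number. From the compounds shown here alone, it also remains open whether 4-bromophenyl or 3-bromophenyl would stand apart as 2-bromophenyl does, and what a longer chain between the sulfur and the ring would do.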